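From a Propyl Amide to a 2-Hydroxyethyl Amide

A few compounds are considered here, and "the series" means these few. Any claim that something is new, unique, unknown or untested is made for them only; others in the source may bear on it.

In a functional assay (muscle tissue) with Rattus norvegicus as the target (a higher number here means that more compound is needed for the effect, a lower number that less compound is needed), compound 1 `CNC(=O)C1=CC(C)(C)Oc2ccc([N+](=O)[O-])cc21` gives 10.7 nM and compound 2 `CCCNC(=O)C1=CC(C)(C)Oc2ccc([N+](=O)[O-])cc21` gives 5.75 nM while compound 3 `CC(C)NC(=O)C1=CC(C)(C)Oc2ccc([N+](=O)[O-])cc21` gives 186 nM on the same shared core. Compound 2 sits at the low end of these numbers, within the scatter of compound 1, and compound 3 lies far higher.

Compound 4 `CC1(C)C=C(C(=O)NCCO)c2cc([N+](=O)[O-])ccc2O1` has not yet been measured and differs from compound 2 in one place. The change hydroxy in place of methyl on a saturated chain carbon, two bonds along the chain from an amide-type nitrogen is hydroxy in place of methyl on a saturated chain carbon, two bonds along the chain from an amide-type nitrogen.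

Two kinds of measured step bear on this change. The step of a 1.9-fold lower number from compound 1 to compound 2 (0.27 log units; within the scatter) is small and alters a straight chain, whereas a 32-fold higher number from compound 2 to compound 3 (1.51 log units; beyond the scatter) and a 17-fold higher number from compound 1 to compound 3 (1.24 log units; beyond the scatter) are large and bring in isopropyl on the amide-type nitrogen. Among the compounds with values here, no measured step places a hydroxy on the chain, so the direction remains uncertain. The chain stays straight, so a jump of the isopropyl size is not expected, and a modest rise is the cautious guess. The expected change a 3.5-fold higher number from compound 2 to compound 4 (0.54 log units; beyond the scatter) in this assay is only an estimate. For compound 4 the estimated value is 20 nM with an expected range from 5 nM to 80 nM in this estimate.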

Compound 4, half-maximal effective concentration: 182 nM
For compound 4 the middle estimate is 9.1-fold (0.96 log units) below the measured one; measured number above the stated range.
By their numbers in this assay, from the lowest: compounds 2 and 1 (each within the scatter of the next); then compounds 4 and 3 (each within the scatter of the next).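

In this assay, hydroxy in place of methyl, on a saturated chain carbon, two bonds along the chain from an amide-type nitrogen, gives a 32-fold higher number from compound 2 to compound 4 (1.50 log units; beyond the scatter) and so shows that a one-atom exchange at this position can matter as much as any step seen so far. The propyl chain had offered no such warning, since a 1.9-fold lower number from compound 1 to compound 2 (0.27 log units; within the scatter) stayed small, while the 2-hydroxyethyl chain gives a 17-fold higher number from compound 1 to compound 4 (1.23 log units; beyond the scatter) on the same shared core. With a 1.0-fold lower number from compound 3 to compound 4 (0.01 log units; within the scatter) as the remaining step, a large move away from compound 1 and compound 2 no longer belongs to isopropyl alone, and 2-hydroxyethyl and isopropyl cannot be told apart in this assay.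

Nothing available explains why this exchange has so large an effect. The compounds shown leave open whether methoxy, an amine or a carboxylic acid at this position, or a longer chain carrying the hydroxy, would stay near compound 4 or return towards compound 2.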